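The compounds below may be only part of what the source reports. "The series", "measured", "known", "first", "only" and "open" are said of these compounds alone.

Series on the shared core of compound 1 `CCOC(=O)C1=C(Nc2ccccc2)S/C(=C\c2ccc(OC)cc2)C1=O`, varying the aryl group on the exocyclic double bond. In a functional assay on JAR cells (Homo sapiens) for inhibition, read by MTT assay, with a stated time of 72 h, tested at 10 uM (on this read-out lower numbers stand for less inhibition and higher numbers for more inhibition at the one concentration tested (going by the name of the read-out)), compound 1 gives 32.9%. Compound 2 `CCOC(=O)C1=C(Nc2ccccc2)S/C(=C\c2ccc(C(=O)O)cc2)C1=O`, with carboxy in place of methoxy on an aromatic carbon, gives 16.8% in this assay and is the lower of the two numbers recorded; the step of a number 16.1 percentage points lower from compound 1 to compound 2 (beyond the scatter). Compound 3 `CCOC(=O)C1=C(Nc2ccccc2)S/C(=C\c2cc[nH]c2)C1=O` is to be measured next. It differs from compound 2 as follows: 1H-pyrrol-3-yl in place of 4-carboxyphenyl on a double-bonded chain carbon bound to a double-bonded ring carbon. Within the data shown here, no measured step bears directly on this change: the only step seen swaps one substituent on the phenyl ring, whereas here the whole 4-carboxyphenyl is exchanged for 1H-pyrrol-3-yl. Compound 2 sits at 16.8% and compound 1 at 32.9%. A modest upward step a number 8.2 percentage points higher from compound 2 to compound 3 (within the scatter) is expected, with wide uncertainty. Compound 3 is therefore estimated at 25% in this assay, within 5% to 45%.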

Compound 3, a percentage reported as inhibition, at one concentration (the size of the read-out at that concentration, not a potency): 19.5%
For compound 3 the middle estimate is 5.5 percentage points above the measured one; measured number inside the range.
By their numbers in this assay, from the lowest: compounds 2 and 3 (each within the scatter of the next); then compound 1.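

Replacing the whole aryl group on a double-bonded chain carbon bound to a double-bonded ring carbon gives a number 2.7 percentage points higher from compound 2 to compound 3 (within the scatter) in this assay, so 1H-pyrrol-3-yl and 4-carboxyphenyl cannot be told apart here, although they differ in ring size and heavy-atom count. Against 4-methoxyphenyl, the same replacement gives a number 13.4 percentage points lower from compound 1 to compound 3 (beyond the scatter), so among these three compounds only compound 1 stands apart, with both steps away from it beyond the scatter. No supporting measurement is available to explain either step.

Going by these compounds, it remains open whether the higher number for compound 1 depends on the methoxy group or on the phenyl ring itself, a question that a plain phenyl group would address. An amine on the phenyl ring, or a methyl group on the pyrrole nitrogen, would further test how this position responds.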